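A few compounds are considered here, and "the series" means these few. Any claim that something is new, unique, unknown or untested is made for them only; others in the source may bear on it.

Compound 1 `COc1cc(CSc2cc(Cl)c(-c3nc(-c4ccc(Cl)cc4)no3)cc2S(=O)(=O)NC(=N)NO)cc(OC)c1OC` was tested in a functional assay on IGROV-1 cells (Homo sapiens) (a lower number here means a stronger inhibitor of growth, a higher number a weaker inhibitor of growth), where compound 1 gives 3800 nM. Within the data shown here, of the two numbers known, this is the highest, but compound 2 `N=C(NO)NS(=O)(=O)c1cc(-c2nc(-c3ccccc3)no2)c(Cl)cc1SCc1ccccc1` gives 2380 nM in this assay, and the gap between the two lies within the usual scatter, so they cannot be told apart. Compound 3 `COc1cc(CSc2cc(Cl)c(-c3nnc(-c4ccc(Cl)cc4)s3)cc2S(=O)(=O)NC(=N)NO)cc(OC)c1OC` has not yet been measured. It differs from compound 1 in one place: 5-(4-chlorophenyl)-1,3,4-thiadiazol-2-yl in place of 3-(4-chlorophenyl)-1,2,4-oxadiazol-5-yl on an aromatic carbon. Among the measured compounds shown here, no measured pair shows the effect of such a change here, so a 1.1-fold lower number from compound 1 to compound 3 (0.04 log units; within the scatter) is expected, a step no larger than the scatter. Compound 3 is therefore estimated at 3500 nM, within a range from 1500 nM to 8000 nM.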

Compound 3, concentration for 50% growth inhibition: 58900 nM
Estimate against measurement, compound 3: 17-fold (1.23 log units) below; measured number outside the range, above it.
By their numbers in this assay, from the lowest: compounds 2 and 1 (each within the scatter of the next); then compound 3.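

In this assay, the change of 3-(4-chlorophenyl)-1,2,4-oxadiazol-5-yl to 5-(4-chlorophenyl)-1,3,4-thiadiazol-2-yl gives a 16-fold higher number from compound 1 to compound 3 (1.19 log units; beyond the scatter) even though both groups have the same heavy-atom, ring and hydrogen-bond counts. At this aromatic carbon, then, matching counts do not make two groups interchangeable. No measurement here explains the loss.

The swap alters both the ring's hetero atoms and their arrangement, so the two effects cannot be separated. A 5-(4-chlorophenyl)-1,3,4-oxadiazol-2-yl group, which keeps the oxygen in the new arrangement, is not among these compounds.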